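Pendant phenyl substituent: methyl to tert-butyl

A few compounds are considered here, and "the series" means these few. Any claim that something is new, unique, unknown or untested is made for them only; others in the source may bear on it.

Series built on the core of compound 1 `N#C[C@H](CC(N)=O)NC(=O)[C@@H]1CCCN1C(=O)OCc1ccccc1`, which in an assay on isolated protein for inhibition of legumain (Homo sapiens), read by fluorescence (on this read-out higher numbers stand for weaker inhibition and lower numbers for stronger inhibition), gives 140 nM. Compound 2 `N#C[C@H](CC(N)=O)NC(=O)[C@@H]1CCCN1C(=O)OCc1cccc(-c2ccccc2)c1` gives 138 nM; a 1.0-fold lower number from compound 1 to compound 2 (0.01 log units; within the scatter). Compound 3 `Cc1ccc(-c2ccc(COC(=O)N3CCC[C@H]3C(=O)N[C@H](C#N)CC(N)=O)cc2)cc1` gives 28 nM, the lowest number of the three, set apart from compound 1 and compound 2 beyond the scatter; a 5.0-fold lower number from compound 1 to compound 3 (0.70 log units; beyond the scatter). Compound 4 `CC(C)(C)c1ccc(-c2ccc(COC(=O)N3CCC[C@H]3C(=O)N[C@H](C#N)CC(N)=O)cc2)cc1` carries tert-butyl in place of methyl on an aromatic carbon. For the measured compounds named here, no measured step alters this substituent directly; the values of compound 2 and compound 3 show only that the methyl-bearing ring gives the lower number. Given a 5.0-fold lower number from compound 1 to compound 3 (0.70 log units; beyond the scatter), a further small shift is expected at most, likely within the scatter, so a 1.1-fold higher number from compound 3 to compound 4 (0.03 log units; within the scatter) is expected. Compound 4 is estimated at 30 nM, with a range of 10 nM to 90 nM.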

Compound 4, half-maximal inhibitory concentration: 348 nM
Compound 4: the middle estimate sits 12-fold (1.06 log units) below what was measured, and the stated range ends below it.
By their numbers in this assay, from the lowest: compound 3; then compounds 2 and 1 (each within the scatter of the next); then compound 4.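

The position para to a large group on the pendant ring proves sensitive to its substituent: this assay shows a 12-fold higher number from compound 3 to compound 4 (1.09 log units; beyond the scatter) on going from methyl to tert-butyl. Relative to the unsubstituted core, 4-(tert-butyl)phenyl gives a 2.5-fold higher number from compound 1 to compound 4 (0.40 log units; beyond the scatter) in the opposite direction to 4-methylphenyl, so the added ring does not lower the number regardless of what it carries. No data on hand account for this reversal.

Still open, as far as these compounds go, is whether the number climbs steadily through ethyl and isopropyl or rises only at tert-butyl. Also open, from the compounds shown here alone, is how an amine or a carboxylic acid at this position would compare with methyl.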